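The compounds below may be only part of what the source reports. "The series", "measured", "known", "first", "only" and "open" are said of these compounds alone.

Compound 1 `OCC1CCN(c2nccnc2OC2CN(c3nc4ccccc4s3)C2)CC1` and compound 2 `c1ccc2nc(N3CC(Oc4nccnc4N4CCCCC4)C3)ccc2c1` are the two members of this small set that have been measured. In a physicochemical assay for solubility, in phosphate buffer, at pH 7.4 (on this read-out lower numbers stand for lower solubility and higher numbers for higher solubility), compound 1 gives 31000 nM. Compound 2 stands at the other end of what has been seen: in this assay compound 2 gives < 1000 nM, which is a limit of the assay rather than a number, as one of the two reported values sits there (the limit of < 1000 nM in this assay, at which 1 of the 2 values shown sits). The two compounds differ in more than one place, so their values can only be set side by side, not read as a single step.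

Compound 3 `c1ccc2nc(N3CC(Oc4nccnc4-c4cncnc4)C3)ccc2c1` has not yet been measured. It differs from compound 2 in one place: pyrimidin-5-yl in place of piperidin-1-yl on an aromatic carbon. Among the measured compounds shown here, no measured pair that differs in one place is available to gauge such a change, so the size of the step has to be expected rather than derived. The step from compound 2 to compound 3 is expected to be a modest one, an at least 1.5-fold higher number from compound 2 to compound 3 (0.17 log units; that floor lies within the scatter), upward but not clearly beyond the scatter. Compound 3 is therefore estimated at 1500 nM, within a range from 300 nM to 6000 nM, with a real chance that this assay again reports only its limit.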

Compound 3, solubility: 254000 nM
Beside the measured number, compound 3's estimate is 170-fold (2.23 log units) below it; measured number above the stated range.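

At this position, on an aromatic carbon next to the ring nitrogen, putting pyrimidin-5-yl in place of piperidin-1-yl gives an at least 250-fold higher number from compound 2 to compound 3 (2.40 log units; beyond the scatter) in this assay. This is the only single change shown, and it establishes that the read-out can move far with the group at this place alone. The exchange swaps a non-aromatic ring for an aromatic one with 2 hetero atoms, while both groups carry 6 heavy atoms and no net charge. In this assay compound 2 gives < 1000 nM, which is a limit of the assay and not a number, and the step can be read only as a floor because of where that value sits: the limit of < 1000 nM in this assay, at which 1 of the 3 values shown sits.

From the compounds shown here alone, what remains open is which feature of the exchange carries the step, the aromatic ring or its ring nitrogens, a question that a phenyl ring or a morpholin-4-yl group at the same carbon would help to separate. Also open, going by these compounds, is whether a step of this size would recur on the core of compound 1, where a different group occupies the far end of the molecule.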